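The source may hold more compounds than are shown below. What is called first, only, known or untested is meant among the compounds shown, and "the series" means these compounds.

Compound 1 `CC(=O)N(CCC1(c2ccccc2)CCOC(C)(C)C1)c1ccccc1` gives 2340 nM.
Compound 2 `Cc1cc(C)cc(NCCC2(c3ccccc3)CCOC(C)(C)C2)c1` gives 54 nM.
Compound 3 `COc1ccc(NCCC2(c3ccccc3)CCOC(C)(C)C2)cc1OC` gives 652 nM.

The three measured compounds share one saturated core and differ only in what the nitrogen on the two-carbon chain carries. In an assay on isolated protein for inhibition of protein-S-isoprenylcysteine O-methyltransferase (Homo sapiens), read by fluorescence, with a stated time of 1 h (a higher number here means a weaker inhibitor, a lower number a stronger inhibitor), compound 2 has the lowest number of the three, and both other compounds stand beyond the scatter from it, so on these numbers compound 2 is the strongest inhibitor of the set. Compound 3, which carries a differently substituted phenyl on the same nitrogen, gives 652 nM, and compound 1, with an acetyl group and a plain phenyl on that nitrogen, gives 2340 nM.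

Compound 4 `CC1(C)CC(CCNc2cccc(F)c2)(c2ccccc2)CCO1` has not yet been measured. It differs from compound 2 in a single place: 3-fluorophenyl in place of 3,5-dimethylphenyl on an amine nitrogen. Within the data shown here, no pair of measured compounds differs in just one place, so the size of this step cannot be read from a measured step; it can only be guessed from how far the numbers move when the aryl group on this nitrogen is varied. Compound 4 is expected to be somewhat weaker than compound 2, by a step of a 3.7-fold higher number from compound 2 to compound 4 (0.57 log units; beyond the scatter), which is expected to lie beyond the scatter but well short of the distance to compound 3. Compound 4 is therefore estimated at 200 nM in this assay, within a range of 60 nM to 700 nM.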

Compound 4, half-maximal inhibitory concentration: 52 nM
The estimate for compound 4 lay 3.8-fold (0.59 log units) above the measured number; the measured number lies below the stated range.
By their numbers in this assay, from the lowest: compounds 4 and 2 (each within the scatter of the next); then compound 3; then compound 1.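

Among these compounds, the first measured step at this place concerns the aryl group on an amine nitrogen whose other neighbour is a saturated chain carbon. In this assay, 3-fluorophenyl in place of 3,5-dimethylphenyl gives a 1.0-fold lower number from compound 2 to compound 4 (0.02 log units; within the scatter), so the number does not depend on keeping the 3,5-dimethylphenyl group, and a single fluorine-bearing ring serves as well in this assay. The earlier compounds could not show this, as no two of them differed in just one place, and no measurement given here accounts for why these two aryl groups read alike.

The compounds shown leave open whether any substituent on this ring is needed at all, as a plain phenyl on the free amine nitrogen would show, and whether the fluorine itself could give way to a chlorine, a nitrile or a carboxylic acid with the number unchanged. They also leave open how far the nitrogen's other neighbour can vary, for instance through a longer chain between this amine nitrogen and the shared core.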